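From 4-methylphenyl to 4-ethylphenyl: expectations for compound 3

A few compounds are considered here, and "the series" means these few. Any claim that something is new, unique, unknown or untested is made for them only; others in the source may bear on it.

Values in a functional assay on MDA-MB-231 cells (Homo sapiens) for antiproliferative activity, read by spectrophotometry and resazurin assay, with a stated time of 72 h; on this read-out lower numbers stand for stronger inhibition and higher numbers for weaker inhibition:
- Compound 1 `CC(C)CC(=O)CC1Oc2cc(O)ccc2C=C1c1ccc(O)cc1`: 67000 nM
- Compound 2 `Cc1ccc(C(=O)CC2Oc3cc(O)ccc3C=C2c2ccc(O)cc2)cc1`: 55000 nM

Compound 2 stands within the scatter of compound 1 in this assay. Compound 3 `CCc1ccc(C(=O)CC2Oc3cc(O)ccc3C=C2c2ccc(O)cc2)cc1` departs from compound 2 by methyl in place of hydrogen on a saturated chain carbon bound to an aromatic carbon. Among the compounds with values here, only one measured step bears on this: a 1.2-fold lower number from compound 1 to compound 2 (0.09 log units; within the scatter), with 4-methylphenyl in place of isobutyl on a carbonyl carbon. With that step inside the scatter, no step beyond the scatter is expected in this assay. The expected step is a 1.1-fold lower number from compound 2 to compound 3 (0.04 log units; within the scatter). The estimate for compound 3 is 50000 nM, with an expected range of 25000 nM to 100000 nM.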

Compound 3, half-maximal inhibitory concentration: 198000 nM
Compound 3: the middle estimate sits 4.0-fold (0.60 log units) below what was measured; the whole stated range lies below it.
By their numbers in this assay, from the lowest: compounds 2 and 1 (each within the scatter of the next); then compound 3.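

In this assay, a single methyl in place of hydrogen on a saturated chain carbon bound to an aromatic carbon is not a silent change: it gives a 3.6-fold higher number from compound 2 to compound 3 (0.56 log units; beyond the scatter) and so moves the number beyond the scatter. The 4-ethylphenyl group also separates from isobutyl, with a 3.0-fold higher number from compound 1 to compound 3 (0.47 log units; beyond the scatter), which 4-methylphenyl did not do. Nothing at hand offers an explanation for this weakening.

Going by these compounds, whether a longer chain, such as propyl, would weaken inhibition further remains open. So does whether an amine or a carboxylic acid on that ring would behave like ethyl or like methyl.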